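Phenylethenyl in place of nitrophenyl on the saturated ring carbon

The source may hold more compounds than are shown below. What is called first, only, known or untested is meant among the compounds shown, and "the series" means these compounds.

Two compounds of this series carry numbers in a functional assay on OVCAR cells (Homo sapiens) for cytotoxicity, read by sulforhodamine B assay, with a stated time of 48 h; a higher number here means a weaker inhibitor, a lower number a stronger inhibitor. Compound 1 `CC(=O)N1N=C(c2cccc([N+](=O)[O-])c2)CC1c1ccccc1` gives 9920 nM in this assay. Compound 2 `O=CCN1N=C(c2ccc3ccccc3c2)CC1c1cccc([N+](=O)[O-])c1` gives 3390 nM in this assay, the lower of the two numbers; its gap to compound 1 lies beyond the scatter of repeated measurements, so compound 2 stands as the stronger inhibitor of the pair. Compound 3 `O=CCN1N=C(c2ccc3ccccc3c2)CC1/C=C/c1ccccc1` has not been measured. It differs from compound 2 in one place: 2-phenylethenyl in place of 3-nitrophenyl on a saturated ring carbon. For the measured compounds named here, no measured pair shows this change, so there is no recorded step to lean on, and the two values at hand say nothing about its size. For compound 3 a step of modest size toward a weaker inhibitor, close to the edge of the scatter, is expected, that is a 1.5-fold higher number from compound 2 to compound 3 (0.17 log units; within the scatter). Compound 3 is accordingly estimated at 5000 nM, with a range from 1500 nM to 16000 nM.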

Compound 3, half-maximal inhibitory concentration: 18100 nM
The estimate for compound 3 lay 3.6-fold (0.56 log units) below the measured number; the whole stated range lies below it.
By their numbers in this assay, from the lowest: compound 2; then compounds 1 and 3 (each within the scatter of the next).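

For the compounds shown here, on the saturated ring carbon next to the ring nitrogen, 2-phenylethenyl in place of 3-nitrophenyl gives the first single-place change that can be read in this assay, and it weakens the series: a 5.3-fold higher number from compound 2 to compound 3 (0.73 log units; beyond the scatter) is beyond the scatter. This position is therefore not indifferent to the group it carries, and with the rest of compound 2 held fixed, the 3-nitrophenyl group gives the stronger inhibitor of this pair. Nothing at hand accounts for the size of this step.

Still open, on these data alone, is whether the nitro group, the ethenyl link or both matter here, which a 3-aminophenyl or a saturated 2-phenylethyl group on the same carbon would help to separate. Also open, as far as these compounds go, is whether a step of this size would recur with a group other than formylmethyl on the ring nitrogen.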